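Swapping a benzylamino arm for a dichlorophenyl sulfanyl arm

The compounds below may be only part of what the source reports. "The series", "measured", "known", "first", "only" and "open" are said of these compounds alone.

Three compounds share one core and differ only in the group attached to it. Compound 1 `Nc1cc(N)c2nc(-c3ccccc3)c(NCc3ccc(Cl)c(Cl)c3)nc2c1` gives 2090 nM in a functional assay on MOLT-4 cells (Homo sapiens) for inhibition, read by sulforhodamine B assay, with a stated time of 48 h; on this read-out higher numbers stand for weaker inhibition of growth and lower numbers for stronger inhibition of growth. Compound 2 `COc1ccc(CNc2nc3cc(N)cc(N)c3nc2-c2ccccc2)cc1OC` gives 3470 nM in this assay, and the step of a 1.7-fold higher number from compound 1 to compound 2 (0.22 log units; within the scatter) stays within the scatter. Compound 3 `Nc1cc(N)c2nc(-c3ccccc3)c(NCc3ccc(F)cc3)nc2c1` gives only a limit, < 100000 nM, in this assay, so where it stands among the others cannot be read; the steps a step that the limit leaves unreadable from compound 1 to compound 3 and a step that the limit leaves unreadable from compound 2 to compound 3 remain unreadable for that reason, as the limit of < 100000 nM in this assay, at which 1 of the 3 values shown sits, records. Compound 4 `Nc1cc(N)c2nc(-c3ccccc3)c(Sc3ccc(Cl)c(Cl)c3)nc2c1` is the next compound, and the change is (3,4-dichlorophenyl)sulfanyl in place of (4-fluorobenzyl)amino on an aromatic carbon. Among the compounds with values here, no measured step touches the sulfanyl link in place of the benzylamino link, so the only guide is that compound 4 carries the same 3,4-dichlorophenyl group as compound 1, which gave 2090 nM. Compound 4 is therefore expected to land near that figure, estimated at 5000 nM with a range from 800 nM to 40000 nM, and the expected step is a step that the limit leaves unreadable from compound 3 to compound 4.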

Compound 4, concentration for 50% growth inhibition: 4070 nM
Estimate against measurement, compound 4: 1.2-fold (0.09 log units) above, within the range that was stated.
By their numbers in this assay, from the lowest: compounds 1, 2 and 4 (each within the scatter of the next).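

No new step can be read, because the comparison of compound 3 with compound 4 rests on a value that is only a limit: the limit of < 100000 nM in this assay, at which 1 of the 4 values shown sits.

The compounds shown leave open how (3,4-dichlorophenyl)sulfanyl and (4-fluorobenzyl)amino on the shared core truly compare in growth inhibition.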